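The source may hold more compounds than are shown below. What is called first, only, known or untested is meant among the compounds shown, and "the series" means these compounds.

Two compounds of the series have numbers in a functional assay on A498 cells (Homo sapiens) for inhibition, read by sulforhodamine B assay, with a stated time of 48 h, tested at 1 uM; a higher number here means a weaker effect of the compound at the concentration tested, a lower number a stronger effect: compound 1 `O=C(Nc1cccc(-n2cc(-c3ccncc3)c(-c3cc(O)cc(Cl)c3)n2)c1)Nc1ccc(Cl)c(Cl)c1` gives 75%, and compound 2 `COc1cc(Cl)cc(-c2nn(-c3cccc(NC(=O)Nc4ccc(Cl)c(Cl)c4)c3)cc2-c2ccncc2)c1` gives 73%. The number of compound 2 sits at the low end of the two, but the step of a number 2 percentage points lower from compound 1 to compound 2 (within the scatter) is within the scatter, so the pair is not distinguished. Compound 3 `COc1cc(Cl)cc(-c2nn(-c3cccc(NC(=O)c4cccc(C(F)(F)F)c4)c3)cc2-c2ccncc2)c1` carries 3-(trifluoromethyl)phenyl in place of (3,4-dichlorophenyl)amino on a carbonyl carbon. For the measured compounds named here, no measured step touches this part of the molecule; the only step known, methyl in place of hydrogen on an oxygen on an aromatic ring, lies elsewhere and was within the scatter, so it sets no direction here. For compound 3 a change of a number 5 percentage points higher from compound 2 to compound 3 (within the scatter) is expected, with wide uncertainty. Compound 3 is therefore estimated at 78%, between 50% and 100%.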

Compound 3, a percentage reported as activity, at one concentration (the size of the read-out at that concentration, not a potency): 51%
For compound 3 the middle estimate is 27 percentage points above the measured one, within the range that was stated.
By their numbers in this assay, from the lowest: compound 3; then compounds 2 and 1 (each within the scatter of the next).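

In this assay, 3-(trifluoromethyl)phenyl in place of (3,4-dichlorophenyl)amino on a carbonyl carbon gives a number 22 percentage points lower from compound 2 to compound 3 (beyond the scatter), so this position responds to change in a way that the methyl on the oxygen, whose step stayed within the scatter, did not show. The step changes the amino link and the ring substituents together, and the two cannot be separated here. No available measurement explains the step.

As far as these compounds go, it remains open whether the amino link or the ring substituents account for the step. From the compounds shown here alone, how a cyclohexyl or a morpholine on the carbonyl carbon would read also remains open.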